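The source may hold more compounds than are shown below. What is called first, only, known or untested is meant among the compounds shown, and "the series" means these compounds.

Measured so far:
Compound 1 `Fc1ccc(-c2cn3ccnc3c(-c3ccc4ncn(C5CCCCC5)c4c3)n2)cc1`: 3.5%
Compound 2 `c1cn2cc(-c3ccsc3)nc(-c3ccc4ncn(C5CCCCC5)c4c3)c2n1`: 4.9%

Going by the values given here, in a functional assay on LOX IMVI cells (Homo sapiens) for inhibition, read by sulforhodamine B assay, with a stated time of 48 h, tested at 10 uM (a lower number here means less inhibition, a higher number more inhibition at the concentration tested (going by the name of the read-out)), compound 2 gives 4.9%, and compound 1 gives 3.5%; the two numbers sit within the usual scatter of each other, so the inhibition in this assay is level between them, and the only step measured, a number 1.4 percentage points higher from compound 1 to compound 2 (within the scatter), is itself within the scatter. Compound 3 `c1csc(-c2cn3ccnc3c(-c3ccc4ncn(C5CCCCC5)c4c3)n2)c1` keeps the shared core of compound 2 and differs from it only by thiophen-2-yl in place of thiophen-3-yl on an aromatic carbon. Among the compounds with values here, the single step that bears on this change is the one from compound 1 to compound 2, where a different five-membered aromatic ring replaced a substituted phenyl at the same place and the read-out hardly moved. An exchange of one thiophenyl for the other at that position is therefore expected to leave the inhibition essentially where compound 2 stands, with no step beyond the scatter; the step expected is a number 0.1 percentage points higher from compound 2 to compound 3 (within the scatter). Compound 3 is estimated to give 5%, in a range from -3% to 15%.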

Compound 3, a percentage reported as inhibition, at one concentration (the size of the read-out at that concentration, not a potency): 1.07%
The estimate for compound 3 lay 3.9 percentage points above the measured number; low and high end bracket the measured number.
By their numbers in this assay, from the lowest: compounds 3, 1 and 2 (each within the scatter of the next).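

In this assay the exchange of thiophen-3-yl for thiophen-2-yl on the aromatic carbon next to the ring nitrogen gives a number 3.8 percentage points lower from compound 2 to compound 3 (within the scatter) and so shows that, at this position, the point at which the thiophenyl ring is attached makes no readable difference. Set against the 4-fluorophenyl group, thiophen-2-yl gives a number 2.4 percentage points lower from compound 1 to compound 3 (within the scatter) and thus joins thiophen-3-yl in reading level with it, so all three aromatic groups now sit within the scatter of one another. Nothing available explains why these groups read alike.

The compounds shown leave open whether a group of another kind at this position, such as an amine or a carboxylic acid, would move the inhibition beyond the scatter. They also leave open whether any change to the shared core away from this position would do so.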